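Octyl in place of pyridin-3-yl: expected Vero cell cytotoxicity

The compounds below may be only part of what the source reports. "The series", "measured", "known", "first", "only" and "open" are said of these compounds alone.

Compound 1 `CN(C)C(=O)C[C@H](CSc1ccccc1)Nc1c(C(=O)N/N=C/c2ccc(Br)s2)cnc2c(C(F)(F)F)cccc12` gives > 62.5 ug/mL in an ADME assay on Vero cells (Chlorocebus sabaeus) for cytotoxicity, read by MTT assay, with a stated time of 72 h (a higher number here means a weaker inhibitor, a lower number a stronger inhibitor), which is a limit of the assay rather than a number.
Compound 2 `COc1ccc(/C=N/NC(=O)c2cnc3c(C(F)(F)F)cccc3c2N[C@@H](CSc2ccccc2)CC(=O)N(C)C)cc1O` gives > 62.5 ug/mL in this assay, also only a limit.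
Compound 3 `CN(C)C(=O)C[C@H](CSc1ccccc1)Nc1c(C(=O)N/N=C/c2cccnc2)cnc2ccc(F)cc12` gives > 62.5 ug/mL in this assay, again only a limit.

Compound 3 thus stands where every measured compound stands: the limit of > 62.5 ug/mL in this assay, at which 3 of the 3 values shown sit. Among the measured compounds shown here, the one measured step, a step that the two limits leave unreadable from compound 1 to compound 2, has limits at both ends and so cannot be read. Compound 4 `CCCCCCCC/C=N/NC(=O)c1cnc2ccc(F)cc2c1N[C@@H](CSc1ccccc1)CC(=O)N(C)C` differs from compound 3 by octyl in place of pyridin-3-yl on a carbon with a double bond to nitrogen. For the measured compounds named here, no measured step involves a change of this kind, so nothing points to a shift in either direction beyond the scatter, and the shared outcome of the three measured compounds suggests compound 4 will most likely also reach the limit. The expected step that the limit leaves unreadable from compound 3 to compound 4 is therefore small. Compound 4 is estimated at 70 ug/mL, between 30 ug/mL and 150 ug/mL.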

Compound 4, half-maximal inhibitory concentration: > 62.5 ug/mL
Compound 4 gave a limit, no number; the forecaster's own chance of this, stated with the estimate: 70%; the middle value is on the limit's open side.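

Among the compounds shown here, compound 3 and compound 4 each give only a limit of the assay, not a number, so no step between them can be read: the limit of > 62.5 ug/mL in this assay, at which 4 of the 4 values shown sit. The compounds shown leave open where any true value lies in this assay, and whether octyl in place of pyridin-3-yl changes it.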